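The source may report more compounds than this note shows. Statements on the series, on what has been measured and on what is new or still open speak of the compounds shown alone.

Measured so far:
compound 1 `COc1ccc(-c2nc(-c3ccccc3)c(-c3ccc4c(c3)NC(=O)CO4)[nH]2)cc1` — 19.1%
compound 2 `O=C1COc2ccc(-c3nn(-c4cc(Cl)cc(Cl)c4)cc3-c3ccccc3)cc2N1` — 52.2%

Both compounds were tested in a functional assay on DLD-1 cells (Homo sapiens) for cytotoxicity, read by colorimetric assay and MTT assay, with a stated time of 3 days, tested at 20 uM; on this read-out lower numbers stand for a stronger effect and higher numbers for a weaker effect at the one concentration tested. Compound 1 gives 19.1%, the lowest of the two numbers, which on this read-out means the stronger effect. Compound 2, built on a different core as its structure shows, gives 52.2%, a number well beyond the usual scatter above that of compound 1. Within the data shown here, no pair of compounds differing in a single place has been measured, so nothing is yet known about how a change at one spot shifts this read-out.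

Compound 3 `O=C1COc2ccc(-c3[nH]c(-c4ccc(Cl)cc4Cl)nc3-c3ccccc3)cc2N1` has not been measured. It differs from compound 1 in one place: 2,4-dichlorophenyl in place of 4-methoxyphenyl on an aromatic carbon. No comparable change has been measured, and the size of the step from compound 1 to compound 3 can only be guessed. A modest shift toward a weaker effect is expected, probably no larger than the scatter, so the step of a number 8.9 percentage points higher from compound 1 to compound 3 (within the scatter) is an estimate rather than a measured fact. For compound 3 in this assay the expected value is 28%, with a likely range from 12% to 50%.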

Compound 3, a percentage reported as activity, at one concentration (the size of the read-out at that concentration, not a potency): 61.9%
The estimate for compound 3 lay 33.9 percentage points below the measured number; measured number outside the range, above it.
By their numbers in this assay, from the lowest: compound 1; then compounds 2 and 3 (each within the scatter of the next).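

In this assay, among these compounds, this is the first single change that can be read, and it shows that the group on the aromatic carbon between two ring nitrogen atoms strongly affects the result. Putting 2,4-dichlorophenyl in place of 4-methoxyphenyl at that carbon gives a number 42.8 percentage points higher from compound 1 to compound 3 (beyond the scatter) and so a clearly weaker effect at the one concentration tested, which means this position is not indifferent to the group it carries on the core of compound 1. No measurement is available that explains the size of this step, and the step alone cannot separate losing the methoxy group from gaining the two chlorine atoms.

The compounds shown leave open whether 4-chlorophenyl or a plain phenyl group at this carbon would read closer to compound 1 or to compound 3, which would help to separate those two parts of the change. They also leave open how a different kind of group on this ring, such as an amine or a carboxylic acid, would behave.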